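The source may report more compounds than this note shows. Statements on the series, on what has been measured and on what is new or still open speak of the compounds shown alone.

For the measured compounds named here, in a functional assay on PC-3 cells (Homo sapiens) for antiproliferative activity, read by sulforhodamine B assay, with a stated time of 48 h, tested at 50 uM (on this read-out higher numbers stand for more inhibition at the one concentration tested (going by the name of the read-out) and lower numbers for less inhibition), compound 2 `CC1=CC[C@H](C(C)C)c2cc(C)c(OC(=O)Nc3ccccc3)cc21` gives 93.2%, the highest of the three numbers measured so far. Compound 1 `Cc1cc2c(C(C)C)ccc(C)c2cc1OC(=O)c1cccc(C(F)(F)F)c1` gives 26.7%, and compound 3 `COc1cccc(C(=O)Oc2cc3c(C)ccc(C(C)C)c3cc2C)c1` gives 12.5%. Going by the values given here, the one measured step, a number 14.2 percentage points lower from compound 1 to compound 3 (beyond the scatter), changes a group on the aromatic ring that sits on the carbonyl carbon, not the link itself, so it bears only loosely on the change considered here. Compound 4 `CC1=CC[C@H](C(C)C)c2cc(C)c(OC(=O)c3ccc(Cl)cc3)cc21` differs from compound 2 in one place: 4-chlorophenyl in place of anilino on a carbonyl carbon. Compound 4 thereby carries, like compounds 1 and 3, an aromatic ring on the carbonyl carbon, and those two compounds gave far lower numbers, although their core also differs. A downward step is therefore expected, a number 48.2 percentage points lower from compound 2 to compound 4 (beyond the scatter), with wide uncertainty. Compound 4 is estimated at 45%, between 15% and 80%.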

Compound 4, a percentage reported as inhibition, at one concentration (the size of the read-out at that concentration, not a potency): 34.1%
The estimate for compound 4 lay 10.9 percentage points above the measured number, within the range that was stated.
By their numbers in this assay, from the lowest: compound 3; then compounds 1 and 4 (each within the scatter of the next); then compound 2.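

In this assay, 4-chlorophenyl in place of anilino on a carbonyl carbon gives a number 59.1 percentage points lower from compound 2 to compound 4 (beyond the scatter). This direct comparison on one shared core shows that the group at this place strongly affects the read-out. No measurement shown here explains the drop. The compounds shown leave open whether losing the anilino nitrogen or gaining the chlorine counts for more. They also leave open how a plain phenyl or a piperidine on that carbonyl carbon would compare.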